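This account rests on a few compounds, and the source may have more. Where it says the series, first, only, none or still open, it means among the compounds named here.

Three nucleoside analogues sharing the same sugar were examined in an ADME assay on Huh-7 cells (Homo sapiens) for cytotoxicity (on this read-out higher numbers stand for lower toxicity in this test and lower numbers for higher toxicity in this test), and a fourth awaits its reading. Compound 1 `C[C@@]1(O)[C@H](O)[C@@H](CO)O[C@H]1c1ccc2c(N)ncnn12` gives > 100000 nM in this assay, a value that is a limit of the assay rather than a number (the limit of > 100000 nM in this assay, at which 1 of the 3 values shown sits). Compound 3 `C[C@@]1(O)[C@H](O)[C@@H](CO)O[C@H]1c1cc(Cl)c2c(N)ncnn12` differs from compound 1 by chloro in place of hydrogen on an aromatic carbon, and in this assay compound 3 gives 6500 nM, so that the change brought an at least 15-fold lower number from compound 1 to compound 3 (1.18 log units; beyond the scatter). Compound 2 `C[C@@]1(O)[C@H](O)[C@@H](CO)O[C@H]1c1cnc2c(N)ncnn12` rests on a core whose difference from the core of compound 1 is not broken down here; in this assay compound 2 gives 26000 nM, the higher of the two numbers measured.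

Compound 4 `C[C@@]1(O)[C@H](O)[C@@H](CO)O[C@H]1c1cnc2c(N)nc(Cl)nn12` differs from compound 2 by chloro in place of hydrogen on an aromatic carbon. Among the measured compounds shown here, this is the same kind of change as the one from compound 1 to compound 3, but not the same: in compound 3 the chloro sits on a five-membered aromatic ring with 1 nitrogen, two ring bonds from the ring nitrogen and two ring bonds from the ring atom that bears a large group, whereas in compound 4 it sits on a six-membered aromatic ring with 3 nitrogen, between two ring nitrogen atoms, two atoms from the ring nitrogen, meta to a fused ring, meta to an amino group and para to a fused ring.

Beside the measured at least 15-fold lower number from compound 1 to compound 3 (1.18 log units; beyond the scatter), a smaller step is expected, a 3.3-fold lower number from compound 2 to compound 4 (0.51 log units; beyond the scatter), starting from the reading of compound 2 at 26000 nM. For compound 4 in this assay the estimate is 8000 nM, expected to fall between 2000 nM and 30000 nM.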

Compound 4, half-maximal cytotoxic concentration: > 100000 nM
Compound 4 was reported as a limit; the forecaster's own chance of this, stated with the estimate: 5%; middle value at least 12-fold (1.09 log units) away from the limit.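

Chloro in place of hydrogen on an aromatic carbon gave an at least 3.8-fold higher number from compound 2 to compound 4 (0.58 log units; beyond the scatter) in this assay, whereas on the other core the same kind of change gave an at least 15-fold lower number from compound 1 to compound 3 (1.18 log units; beyond the scatter), so the change did not carry from one core to the other, either in direction or in size: the same change on two cores in this assay, an at least 15-fold lower number (1.18 log units; beyond the scatter) from compound 1 to compound 3 and an at least 3.8-fold higher number (0.58 log units; beyond the scatter) from compound 2 to compound 4, at least 59-fold (1.77 log units) apart, beyond the scatter of two such steps

Compound 4 stands at > 100000 nM, which is a limit of the assay and not a number, so the true size of its step stays unknown, and the same limit also bounds the step that starts from compound 1: the limit of > 100000 nM in this assay, at which 2 of the 4 values shown sit.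

The two pairs do not show what lies behind the difference, for the chloro sits on a different ring in each case, so the effect of the core cannot be told apart from that of the place, and two pairs set no rule for any further core in the series.

Left open is whether an amine, a methoxy group or a bromo group at the same place on the core of compound 2 would also reach the limit of the assay. Also open, going by these compounds, is whether chloro on the six-membered ring of the core of compound 1 would follow compound 3 or compound 4.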